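Lengthening the Amide Chain and Dropping the Fluorine

The source may hold more compounds than are shown below. What is called first, only, known or untested is meant among the compounds shown, and "the series" means these compounds.

Three compounds share one core and differ only in the group attached to the amide nitrogen. Compound 1 `CC(C)C(NS(=O)(=O)Cc1ccccc1)C(=O)N1CCC(c2ccc(Cl)cc2)CC1` in an assay on THP-1 cells for displacement of a labelled ligand from C-C chemokine receptor type 1 (Homo sapiens) (on this read-out lower numbers stand for stronger inhibition and higher numbers for weaker inhibition), gives 303 nM. Compound 2 `CC(C)[C@@H](NC(=O)CCc1ccc(F)cc1)C(=O)N1CCC(c2ccc(Cl)cc2)CC1` in this assay gives 70 nM. Compound 3 `CC[C@@H](C)[C@@H](NC(=O)c1ccccc1)C(=O)N1CCC(c2ccc(Cl)cc2)CC1` in this assay gives 45 nM. Among these three numbers compound 2 stands second highest: its gap to compound 3 lies within the usual scatter, while compound 1 sits beyond the scatter at the weaker end.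

Compound 4 `CC(C)[C@@H](NC(=O)CCCc1ccccc1)C(=O)N1CCC(c2ccc(Cl)cc2)CC1` differs from compound 2 in one place: benzyl in place of 4-fluorophenyl on a saturated chain carbon, two bonds along the chain from a carbonyl carbon. For the measured compounds named here, no measured pair shows this exact change, so no direct step is known. Because compound 2 gives 70 nM and compound 3 gives 45 nM, the variations of this side chain seen so far move the number little. A small step is therefore expected, a 1.4-fold higher number from compound 2 to compound 4 (0.15 log units; within the scatter), with no clear direction beyond the scatter. Compound 4 is estimated at 100 nM, within a range from 35 nM to 300 nM.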

Compound 4, half-maximal inhibitory concentration: 95 nM
Beside the measured number, compound 4's estimate is 1.1-fold (0.02 log units) above it; the range from low to high includes it.
By their numbers in this assay, from the lowest: compounds 3, 2 and 4 (each within the scatter of the next, the first and the last beyond it); then compound 1.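

Setting benzyl in place of 4-fluorophenyl on a saturated chain carbon, two bonds along the chain from a carbonyl carbon, gives a 1.4-fold higher number from compound 2 to compound 4 (0.13 log units; within the scatter) in this assay. For the compounds shown here, this is the first direct comparison at this place, and it shows that a 3-phenylpropyl chain can stand in for a 2-(4-fluorophenyl)ethyl chain with no difference that can be told from the scatter. No measurement shown here explains this result.

As far as these compounds go, the chain length and the fluorine change together in this pair, so what a phenethyl or a 3-(4-fluorophenyl)propyl chain would give, and thus the separate share of each change, remains open. Also open, from the compounds shown here alone, is how a longer chain, or an amine or a carboxylic acid on this chain, would read.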